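This account rests on a few compounds, and the source may have more. Where it says the series, first, only, none or still open, it means among the compounds named here.

Compound 3 `COc1ccc(-c2ccc3ncn(-c4cc(OC)c(OC)c(OC)c4)c3c2)cc1` carries a 4-methoxyphenyl on the shared core. In a functional assay on SGC-7901 cells (Homo sapiens) for antiproliferative activity, read by MTT assay, with a stated time of 72 h (a higher number here means a weaker inhibitor, a lower number a stronger inhibitor), compound 3 gives 82 nM. Compound 1 `COc1cc(-n2cnc3ccc(-c4ccc([N+](=O)[O-])cc4)cc32)cc(OC)c1OC` carries nitro where compound 3 carries methoxy. In this assay compound 1 gives 79 nM, and a 1.0-fold higher number from compound 1 to compound 3 (0.02 log units; within the scatter). Compound 2 `COc1cc(-n2cnc3ccc(-c4ccc(C(F)(F)F)cc4)cc32)cc(OC)c1OC`, with trifluoromethyl at that place, gives 890 nM in this assay, so compound 3 stands second highest of the three numbers, with an 11-fold lower number from compound 2 to compound 3 (1.04 log units; beyond the scatter); in the same way an 11-fold higher number from compound 1 to compound 2 (1.05 log units; beyond the scatter). Compound 4 `COc1cc(-n2cnc3ccc(-c4cccc(Cl)c4)cc32)cc(OC)c1OC` has not yet been measured. The change is 3-chlorophenyl in place of 4-methoxyphenyl on an aromatic carbon. Both measured steps swap the group on the pendant ring, and they show that such a swap can be neutral, as between nitro and methoxy, or large, as with trifluoromethyl. Neither step involves a 3-chlorophenyl, so the size of this step is uncertain. A moderate weakening is expected, a 3.7-fold higher number from compound 3 to compound 4 (0.56 log units; beyond the scatter), sitting between the two measured outcomes. The estimate for compound 4 in this assay is 300 nM, with a range from 80 nM to 1500 nM.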

Compound 4, half-maximal inhibitory concentration: 1490 nM
Compound 4: middle estimate off by 5.0-fold (0.70 log units), on the low side; measured number inside the range.
By their numbers in this assay, from the lowest: compounds 1 and 3 (each within the scatter of the next); then compounds 2 and 4 (each within the scatter of the next).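

In this assay, the change to 3-chlorophenyl is large against the 4-methoxyphenyl (an 18-fold higher number from compound 3 to compound 4 (1.26 log units; beyond the scatter)) and also large against the 4-nitrophenyl (a 19-fold higher number from compound 1 to compound 4 (1.28 log units; beyond the scatter)), while against the 4-(trifluoromethyl)phenyl it stays within the scatter (a 1.7-fold higher number from compound 2 to compound 4 (0.22 log units; within the scatter)). The four groups at this position therefore fall into two tiers, and 3-chlorophenyl joins 4-(trifluoromethyl)phenyl in the tier with the higher numbers, showing that a weak result here is not confined to one group. No measurement shown here accounts for this split.

This step changes both the substituent and its place on the pendant ring, so the compounds leave open which of the two matters. Going by these compounds, whether an amine or a carboxylic acid on that ring would give a number in the lower or the higher tier also remains open.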